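The source may report more compounds than this note shows. Statements on the series, on what has been measured and on what is new or still open speak of the compounds shown alone.

In a functional assay on HOP-92 cells (Homo sapiens) for inhibition, read by sulforhodamine B assay, with a stated time of 48 h (on this read-out lower numbers stand for stronger inhibition of growth and higher numbers for weaker inhibition of growth), compound 1 `COc1cc(C)cc(-c2c(-c3ccnc(-c4ccc(C(C)=O)cc4)c3)cnn2CC#N)c1` gives 1460 nM. Compound 2 `COc1cc(C)cc(-c2nn(CC#N)cc2-c2ccc(-c3cccc(C(C)=O)c3)nc2)c1` gives 2630 nM and compound 3 `Cc1cc(O)cc(-c2nn(CC#N)cc2-c2ccnc(-c3ccc(Oc4ccccc4)cc3)c2)c1` gives 1590 nM. Compound 1 carries the lowest of the three numbers, yet the gaps to both other compounds lie within the usual scatter, so no order among the three can be read from these values. Compound 4 `COc1cc(C)cc(-c2c(-c3ccnc(-c4ccc(N(C)C)cc4)c3)cnn2CC#N)c1` has not yet been tested. It differs from compound 1 in one place: dimethylamino in place of acetyl on an aromatic carbon. Among the compounds with values here, no pair of tested compounds shows this kind of exchange, so nothing here sizes the step directly. The expectation is for a step no larger than the scatter, in either direction, and the value expected for compound 4 in this assay is 1500 nM, with a range from 500 nM to 4500 nM, meaning an expected 1.0-fold higher number from compound 1 to compound 4 (0.01 log units; within the scatter).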

Compound 4, concentration for 50% growth inhibition: < 10 nM
Compound 4: no number, only a limit; the forecaster's own chance of this, stated with the estimate: 5%; middle value at least 150-fold (2.17 log units) from the limit.
By their numbers in this assay, from the lowest: compounds 1, 3 and 2 (each within the scatter of the next). At a limit, below all of these: compound 4.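

Going from 4-acetylphenyl to 4-(dimethylamino)phenyl in this assay gives an at least 140-fold lower number from compound 1 to compound 4 (2.16 log units; beyond the scatter). This position is therefore highly sensitive to the group it carries, even though 3 heavy atoms replace 3 heavy atoms and each group has 1 hydrogen-bond acceptor. Compound 4 gives < 10 nM, which is a limit and not a number: the limit of < 10 nM in this assay, at which 1 of the 4 values shown sits.

How a primary amine or a methoxy group at this place would compare with dimethylamino cannot be told from these compounds. They also do not show whether the same exchange would have a similar effect on the core of compound 2.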